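A few compounds are considered here, and "the series" means these few. Any claim that something is new, unique, unknown or untested is made for them only; others in the source may bear on it.

Working notes on a small series of 2-chlorobenzyl and 3-chlorobenzyl sulfanyl analogues.

Compound 1 `COc1ccc(C2N=C(SCc3ccccc3Cl)NC(C)=C2C(=O)Nc2ccc(F)cc2)cc1OC` gives 17% in a functional assay on the whole organism (artery, strain albino) with Rattus norvegicus as the target, with a stated time of 120 min, at a dose of 10 mg/kg by the oral route; on this read-out lower numbers stand for less inhibition and higher numbers for more inhibition at the one dose given (going by the name of the read-out). Compound 2 `COc1ccc(C2N=C(SCc3cccc(Cl)c3)NC(C)=C2C(=O)Nc2ccc(F)cc2)cc1OC` carries the change 3-chlorophenyl in place of 2-chlorophenyl on a saturated chain carbon bound to a sulfur and gives 10.8% in this assay; the step is a number 6.2 percentage points lower from compound 1 to compound 2 (within the scatter). Compound 3 `CC1=C(C(=O)Nc2ccc([N+](=O)[O-])cc2)C(c2ccc(Br)cc2)N=C(SCc2ccccc2Cl)N1` differs from compound 1 in more than one place, and the difference between the two cores is not broken down here. In this assay compound 3 gives 7.7%, which sits within the scatter of both compound 1 and compound 2, so no order among the three can be read.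

Compound 4 `CC1=C(C(=O)Nc2ccc([N+](=O)[O-])cc2)C(c2ccc(Br)cc2)N=C(SCc2cccc(Cl)c2)N1` stands to compound 3 as compound 2 stands to compound 1: the change is 3-chlorophenyl in place of 2-chlorophenyl on a saturated chain carbon bound to a sulfur, the same change at the same place. For the measured compounds named here, the only measured instance of it, from compound 1 to compound 2, stayed within the scatter, so the expected step of a number 2.7 percentage points lower from compound 3 to compound 4 (within the scatter) is set small, resting on a number 6.2 percentage points lower from compound 1 to compound 2 (within the scatter). The expected value for compound 4 in this assay is 5%, with a range from 0% to 15%, acknowledging that one prior step is a thin basis.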

Compound 4, a percentage reported as inhibition, in the whole organism at one dose (the size of the read-out at that dose, not a potency): 6.7%
Compound 4: the middle estimate sits 1.7 percentage points below what was measured; measured number inside the range.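

Across the two cores, the change from 2-chlorobenzyl to 3-chlorobenzyl reads the same way in this assay. On the core of compound 3 it comes out as a number 1 percentage points lower from compound 3 to compound 4 (within the scatter), and the two instances cannot be told apart: the same change on two cores in this assay, a number 6.2 percentage points lower (within the scatter) from compound 1 to compound 2 and a number 1 percentage points lower (within the scatter) from compound 3 to compound 4, 5.2 percentage points apart, within the scatter of two such steps. This shows only that no effect of the change can be read on either core at the one dose given; it does not show that the change is without effect, nor how it would behave on any other core.

As far as these compounds go, the cores of compound 1 and compound 3 differ in more than one place, so the contribution of each part to the read-out stays open, and a core on which the change gives a step beyond the scatter is still to be seen. Also open, from the compounds shown here alone, is what a plain benzyl, a longer alkyl chain or a chain ending in an amine or a carboxylic acid would give on the sulfur.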